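Extending the side chain of compound 3 toward an acid

The source may report more compounds than this note shows. Statements on the series, on what has been measured and on what is new or still open speak of the compounds shown alone.

Compound 1 `O=c1c(-c2ccc(O)cc2)coc2cc(OCCOCCOCCO)ccc12` gives 40 nM in an assay (Cricetulus griseus) for inhibition of aldehyde dehydrogenase, mitochondrial (Homo sapiens); a higher number here means a weaker inhibitor, a lower number a stronger inhibitor.
Compound 2 `CCCCCCOc1ccc2c(=O)c(-c3ccc(O)cc3)coc2c1` gives 1500 nM in this assay.
Compound 3 `NCCCCOc1ccc2c(=O)c(-c3ccc(O)cc3)coc2c1` gives 250 nM in this assay.

Compound 3 stands second highest of the three numbers, with compound 2 nearest and compound 1 furthest. Compound 4 `O=C(O)CCCCCCCCCOc1ccc2c(=O)c(-c3ccc(O)cc3)coc2c1` differs from compound 3 by 5-carboxypentyl in place of amino on a saturated chain carbon, four bonds along the chain from an oxygen on an aromatic ring. The step of a 6.0-fold lower number from compound 2 to compound 3 (0.78 log units; beyond the scatter) bears most directly on this change, since it swaps a carbon group for the amino at the same place; a 38-fold higher number from compound 1 to compound 2 (1.57 log units; beyond the scatter) shows that an oxygen-rich chain outperforms a plain alkyl chain here. Compound 4 gives up the amino but ends its chain in a carboxylic acid, so the expected step of a 2.4-fold higher number from compound 3 to compound 4 (0.38 log units; beyond the scatter) is modest and toward a higher number. Compound 4 is estimated at 600 nM, between 150 nM and 2500 nM.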

Compound 4, half-maximal inhibitory concentration: 50 nM
The estimate for compound 4 lay 12-fold (1.08 log units) above the measured number, outside the stated range (below it).
By their numbers in this assay, from the lowest: compounds 1 and 4 (each within the scatter of the next); then compound 3; then compound 2.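

In this assay, a long chain ending in a carboxylic acid is well tolerated at this position, giving a lower number than either the shorter amine chain (a 5.0-fold lower number from compound 3 to compound 4 (0.70 log units; beyond the scatter)) or the plain alkyl chain (a 30-fold lower number from compound 2 to compound 4 (1.48 log units; beyond the scatter)). An oxygen-rich chain is therefore not the only route to a low number, as the acid chain and that chain cannot be told apart (a 1.3-fold higher number from compound 1 to compound 4 (0.10 log units; within the scatter)). Nothing measured here explains this. Still open, on these data alone, is whether the acid or the chain length matters more: a shorter chain ending in a carboxylic acid, or an equally long chain ending in an amine, would separate the two.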